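The source may hold more compounds than are shown below. What is called first, only, known or untested is meant among the compounds shown, and "the series" means these compounds.

Measured so far:
compound 1, `c1ccc(-c2ccncn2)c(OCC2=NCCN2)c1`: < 100000 nM (a limit)
compound 2, `c1ccc(-c2cc[nH]n2)c(OCC2=NCCN2)c1`: 5.01 nM

In a functional assay for activation of Alpha-1A adrenergic receptor (Homo sapiens), read by calcium flux (on this read-out lower numbers stand for an effect already at smaller amounts and higher numbers for an effect only at larger amounts of compound), compound 1 gives < 100000 nM, which is a limit of the assay rather than a number. In this assay compound 2 gives 5.01 nM; this is the only number shown. The step that the limit leaves unreadable from compound 1 to compound 2 therefore cannot be sized. Compound 3, `Cn1nccc1-c1ccccc1OCC1=NCCN1`, has not yet been measured in this assay. It differs from compound 2 by 1-methyl-1H-pyrazol-5-yl in place of 1H-pyrazol-3-yl on an aromatic carbon. Among the measured compounds shown here, no measured step touches this change: the one step recorded, from compound 1 to compound 2, is unreadable because of the limit of < 100000 nM in this assay, at which 1 of the 2 values shown sits, so it gives neither a size nor a direction for the new step. The expectation for compound 3 therefore rests on compound 2 alone, and it is wide: a weakening of moderate size is expected in this assay, a 40-fold higher number from compound 2 to compound 3 (1.60 log units; beyond the scatter), while a value within the scatter of compound 2 cannot be ruled out. Compound 3 is expected to give 200 nM, between 10 nM and 5000 nM.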

Compound 3, half-maximal effective concentration: 39.8 nM
The estimate for compound 3 lay 5.0-fold (0.70 log units) above the measured number; measured number inside the range.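

In this assay, among the compounds shown here, putting 1-methyl-1H-pyrazol-5-yl in place of 1H-pyrazol-3-yl gives a 7.9-fold higher number from compound 2 to compound 3 (0.90 log units; beyond the scatter), the first step whose size can be read. This place on the six-membered aromatic ring, ortho to a group of 7 heavy atoms, is therefore sensitive to the change but does not lose activation, since compound 3, whose new group has 0 hydrogen-bond donors, still gives a real number of 39.8 nM. Compound 1 gives only a limit, so neither step starting from it can be read: the limit of < 100000 nM in this assay, at which 1 of the 3 values shown sits.

The change alters two things at once, adding a methyl group and moving the ring's point of attachment from its 3-carbon to its 5-carbon, so the step cannot be divided between them, and 1-methyl-1H-pyrazol-3-yl, with the methyl but the original attachment, would be the direct test. On these data alone, how much room exists on that ring nitrogen also remains open, as a longer chain such as ethyl or a cyclopropyl group could weaken the number further or leave it unchanged.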